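Ethyl in place of cyano: a stability estimate

The source may report more compounds than this note shows. Statements on the series, on what has been measured and on what is new or still open speak of the compounds shown alone.

In an ADME assay (liver) for metabolic stability, with Liver microsome (Canis lupus familiaris) as the target, read by LC-MS, using microsomes, with a stated time of 30 min, tested at 4 uM (a higher number here means that more of the compound is left, a lower number that less of the compound is left), compound 2 `Cc1nc(N2CCN(C)CC2)c2nc(-c3ccccc3C#N)n(C3CCOCC3)c2n1` gives 11% and sits lowest of the two measured compounds. Going by the values given here, compound 1 `Cc1nc(N2CCN(C)CC2)c2nc(-c3cccc(Cl)c3)n(C3CCOCC3)c2n1` gives 45% as the only other number so far. Compound 3 `CCc1ccccc1-c1nc2c(N3CCN(C)CC3)nc(C)nc2n1C1CCOCC1` carries ethyl in place of cyano on an aromatic carbon ortho to a large group. Among the compounds with values here, the one measured step of a number 34 percentage points lower from compound 1 to compound 2 (beyond the scatter) was large and beyond the scatter, yet it brought in the cyano group that now leaves and removed a different group, so it guides only loosely. A modest rise within the scatter is expected, with the estimate a number 7 percentage points higher from compound 2 to compound 3 (within the scatter) as its size. For compound 3 the estimated value is 18% with a range from 5% to 40% expected.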

Compound 3, percent of the compound remaining: 74%
Beside the measured number, compound 3's estimate is 56 percentage points below it, and the stated range ends below it.
By their numbers in this assay, from the lowest: compound 2; then compound 1; then compound 3.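

The place on an aromatic carbon ortho to a large group proves highly sensitive to which group sits there in this assay: ethyl in place of cyano gives a number 63 percentage points higher from compound 2 to compound 3 (beyond the scatter) despite both groups having 2 heavy atoms. The 2-ethylphenyl group also compares well with 3-chlorophenyl, with a number 29 percentage points higher from compound 1 to compound 3 (beyond the scatter) in this comparison, so among these compounds the low number goes with cyano and not with the place alone. Nothing measured here explains the difference between the two groups. From the compounds shown here alone, whether methyl, a longer chain such as propyl, or an amine at this place would keep the number as high remains open.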